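Removing one phenyl from the piperazine side chain of compound 1

The source may hold more compounds than are shown below. What is called first, only, known or untested is meant among the compounds shown, and "the series" means these compounds.

Compound 1 `Nc1ccccc1NC(=O)c1ccc(CSC(=S)N2CCN(C(c3ccccc3)c3ccccc3)CC2)cc1` is the weaker of the two compounds measured in a functional assay on A-375 cells (Homo sapiens) for antiproliferative activity, read by CCK-8 assay, with a stated time of 72 h, tested at 2 uM; on this read-out higher numbers stand for a stronger effect at the one concentration tested and lower numbers for a weaker effect; there compound 1 gives 8.7%, whereas compound 2 `CN(Cc1ccncc1)C(=S)SCc1ccc(C(=O)Nc2ccccc2N)cc1` gives 31.4%, a gap beyond the usual scatter. Compound 3 `Nc1ccccc1NC(=O)c1ccc(CSC(=S)N2CCN(Cc3ccccc3)CC2)cc1` has not yet been measured. It differs from compound 1 by hydrogen in place of phenyl on a saturated chain carbon bound to an amine nitrogen in a ring and an aromatic carbon. For the measured compounds named here, with no measured pair showing this exact change, only a small upward step is expected, one that need not exceed the scatter: the expected step of a number 6.3 percentage points higher from compound 1 to compound 3 (within the scatter) in this assay is modest. Compound 3 is therefore estimated at 15%, within a range from 3% to 35%.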

Compound 3, a percentage reported as inhibition, at one concentration (the size of the read-out at that concentration, not a potency): 10.6%
For compound 3 the middle estimate is 4.4 percentage points above the measured one; the measured number falls inside the stated range.
By their numbers in this assay, from the lowest: compounds 1 and 3 (each within the scatter of the next); then compound 2.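

Replacing phenyl with hydrogen on this saturated chain carbon gives a number 1.9 percentage points higher from compound 1 to compound 3 (within the scatter) in this assay. One of the two phenyl groups at this position can therefore go without a shift that stands out from the scatter, so the second phenyl is not needed to keep the read-out where it is at this single concentration. Nothing measured here offers a reason for this outcome.

Going by these compounds, it remains open whether a carboxylic acid or an amine on the remaining phenyl would move the number beyond the scatter. On these data alone, it is also open whether replacing that phenyl with a longer chain would do so.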